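The source may report more compounds than this note shows. Statements on the series, on what has been measured and on what is new or still open speak of the compounds shown alone.

Working notes on a small set of thiazolidinedione-bearing compounds examined in an assay for inhibition of glutaminase kidney isoform, mitochondrial (Homo sapiens), read by coupled enzyme assay, with stated times of 10 min and 60 min; on this read-out higher numbers stand for weaker inhibition and lower numbers for stronger inhibition. Compound 1 `COc1cc(-n2c(-c3ccccc3)cc(/C=C3\SC(=O)NC3=O)c2-c2ccccc2)ccc1-c1ccc(/C=C2\SC(=O)NC2=O)cc1` gives 148 nM. Compound 2 `COc1cc(-n2c(C)cc(/C=C3\SC(=O)NC3=O)c2C)ccc1-c1ccc(/C=C2\SC(=O)NC2=O)cc1` gives 355 nM. Compound 3 `Cc1cc(/C=C2\SC(=O)NC2=O)c(C)n1-c1ccc(Br)cc1` gives 5370 nM. On these three numbers compound 2 stands second highest: its nearest neighbour is compound 1, whose number is lower by a gap beyond the usual scatter, and its furthest is compound 3, whose number is higher by a much larger gap, also beyond the scatter. For the measured compounds named here, no pair among the measured compounds differs in a single place, so none of these gaps can be assigned to one change.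

Compound 4 `Cc1cc(/C=C2\SC(=O)NC2=O)c(C)n1-c1ccc(-c2ccc(/C=C3\SC(=O)NC3=O)cc2)cc1` differs from compound 2 in one place: hydrogen in place of methoxy on an aromatic carbon, in words hydrogen in place of methoxy on an aromatic carbon. Compound 3 also lacks the methoxy, yet it also lacks the second thiazolidinedione-bearing ring, so its value cannot be read as the effect of the methoxy alone. Going by the values given here, with no measured step isolating this change, the expectation in this assay this assay is a step of no size beyond the scatter, with at most a slight lean toward a higher number. For compound 4 the estimated value in this assay is 500 nM, with a range from 150 nM to 1600 nM. This estimate corresponds to an expected step of a 1.4-fold higher number from compound 2 to compound 4 (0.15 log units; within the scatter).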

Compound 4, half-maximal inhibitory concentration: 381 nM
The estimate for compound 4 lay 1.3-fold (0.12 log units) above the measured number; the measured number falls inside the stated range.
By their numbers in this assay, from the lowest: compound 1; then compounds 2 and 4 (each within the scatter of the next); then compound 3.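

In this assay, for the compounds shown here, the pair compound 2 and compound 4 gives the first step that isolates a single change, and that step, a 1.1-fold higher number from compound 2 to compound 4 (0.03 log units; within the scatter) for hydrogen in place of methoxy on an aromatic carbon, leaves the two numbers indistinguishable. At this position, ortho to a large group and meta to a large group, the methoxy is therefore dispensable in this pair: without it, compound 4 still reads 381 nM in this assay, so the exchange of these two substituents does not register on this read-out. No measurement at hand offers an explanation for the absence of a measurable step here.

Still open, on these data alone, is whether this position would tolerate other substituents equally well: an amine, a carboxylic acid or a longer chain such as ethoxy might leave the number where it stands or might shift it well beyond the scatter. Also open, as far as these compounds go, is whether the same hydrogen-for-methoxy exchange would be just as silent on the core of compound 1, since the present step comes from a single pair of compounds.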